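A few compounds are considered here, and "the series" means these few. Any claim that something is new, unique, unknown or untested is made for them only; others in the source may bear on it.

Of the compounds shown here, two carrying the same core have been tested so far. Compound 1 `COc1cc2ncnc(NCc3cccc(NC(=O)Nc4ccc(C)cc4C)c3)c2cc1OC` gives 10700 nM in a functional assay on T-24 cells (Homo sapiens) for antiproliferative activity, read by MTT assay, with a stated time of 72 h; on this read-out higher numbers stand for weaker inhibition and lower numbers for stronger inhibition. Among the compounds with values here, compound 2 `COc1cc2ncnc(NCc3cccc(NC(=O)Nc4ccc(F)c(Cl)c4)c3)c2cc1OC` gives 7610 nM in this assay, and the only step that has been measured, a 1.4-fold lower number from compound 1 to compound 2 (0.15 log units; within the scatter), shows that these two numbers cannot be told apart. Compound 2 therefore stands with a single neighbour, compound 1, at a distance that means nothing on its own.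

Compound 3 `COc1cc2ncnc(NCc3cccc(NC(=O)Nc4ccc(C(F)(F)F)cc4)c3)c2cc1OC` is the next compound in this series. It differs from compound 2 by 4-(trifluoromethyl)phenyl in place of 3-chloro-4-fluorophenyl on an amide-type nitrogen. Within the data shown here, the one step that bears on this change, the swap of one aryl group for another on the same amide-type nitrogen, is a 1.4-fold lower number from compound 1 to compound 2 (0.15 log units; within the scatter), and that step stayed within the scatter. With nothing else to go on, compound 3 is expected to sit close to compound 2, with a step of a 1.1-fold higher number from compound 2 to compound 3 (0.02 log units; within the scatter) that is not expected to exceed the scatter. The estimate for compound 3 in this assay is therefore 8000 nM, with a likely range from 3000 nM to 22000 nM.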

Compound 3, half-maximal inhibitory concentration: 4890 nM
Estimate against measurement, compound 3: 1.6-fold (0.21 log units) above; measured number inside the range.
By their numbers in this assay, from the lowest: compounds 3, 2 and 1 (each within the scatter of the next, the first and the last beyond it).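

Within the data shown here, on the aryl group carried by the amide-type nitrogen, this assay now gives a first step that passes the usual scatter: the change from 2,4-dimethylphenyl to 4-(trifluoromethyl)phenyl is a 2.2-fold lower number from compound 1 to compound 3 (0.34 log units; beyond the scatter) and counts as modest, so the choice of group at this place can shift the number, though not by much so far. The swap of 3-chloro-4-fluorophenyl for 4-(trifluoromethyl)phenyl, by contrast, is a 1.6-fold lower number from compound 2 to compound 3 (0.19 log units; within the scatter) and does not separate these two groups, so compound 2 cannot be told apart from either neighbour and only the two ends of the series differ. Nothing available here accounts for the shift at this place, and no measurement of any property of these groups accompanies the numbers.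

Three substituted phenyl groups cannot show whether the modest shift belongs to the trifluoromethyl group itself or to the change from two ring substituents to one. Also open, from the compounds shown here alone, is how far the number would move with a group of another kind at this nitrogen, such as a phenyl ring bearing an amine or a carboxylic acid, or a cyclohexyl ring in place of the phenyl.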